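The source may hold more compounds than are shown below. What is called first, only, known or untested is meant among the compounds shown, and "the series" means these compounds.

In a functional assay on K562 cells (Homo sapiens) for cytotoxicity, read by trypan blue exclusion, with a stated time of 96 h (a lower number here means a stronger inhibitor, a higher number a weaker inhibitor), compound 1 `COc1ccc(/C=C/S(=O)(=O)Cc2ccc(OC)c(N)c2)c(OC)c1` gives 500 nM and compound 2 `COc1ccc(OC)c(/C=C/S(=O)(=O)Cc2ccc(OC)c(N)c2)c1` gives 750 nM, two values within the usual scatter of each other. Compound 3 `COc1ccc(CS(=O)(=O)/C=C/c2cc(OC)c(OC)cc2OC)cc1N` differs from compound 2 by methoxy in place of hydrogen on an aromatic carbon, with methoxy in place of hydrogen on an aromatic carbon. Among the compounds with values here, no measured step shows what this change does. Within the data shown here, with compound 1 at 500 nM and compound 2 at 750 nM as the only guide, no step beyond the scatter is expected in this assay. The estimated 1.5-fold lower number from compound 2 to compound 3 (0.18 log units; within the scatter) therefore stays small. Compound 3 is expected to give 500 nM, within an estimated range of 150 nM to 1500 nM.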

Compound 3, half-maximal inhibitory concentration: 250 nM
For compound 3 the middle estimate is 2.0-fold (0.30 log units) above the measured one; low and high end bracket the measured number.
By their numbers in this assay, from the lowest: compounds 3, 1 and 2 (each within the scatter of the next, the first and the last beyond it).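

In this assay, within the data shown here, methoxy in place of hydrogen on an aromatic carbon, para to a large group, gives a 3.0-fold lower number from compound 2 to compound 3 (0.48 log units; beyond the scatter) and so provides the first step here beyond the scatter. The same kind of replacement gives a 2.0-fold lower number from compound 1 to compound 3 (0.30 log units; within the scatter) and stays within the scatter, so the clear step holds against compound 2 only. Nothing measured here gives a reason for this step. On these data alone, whether ethoxy, hydroxyl or fluorine at that para position would give a comparable step remains open. So does whether the step would persist if the amine on the other ring were replaced by a hydroxyl.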